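Removing a Methoxy Group From Compound 1

A few compounds are considered here, and "the series" means these few. Any claim that something is new, unique, unknown or untested is made for them only; others in the source may bear on it.

Within the data shown here, compound 1 `COc1ccc(CNCCCNS(=O)(=O)c2cc(C(F)(F)F)cc(C(F)(F)F)c2)cc1OC` is one of three compounds measured in a functional assay on MCF7 cells (Homo sapiens) for inhibition, read by MTT assay, with a stated time of 72 h (a lower number here means a stronger inhibitor of growth, a higher number a weaker inhibitor of growth), where compound 1 gives 1900 nM. Compound 2 `O=S(=O)(NCCCNCC1COc2ccccc2O1)c1cc(C(F)(F)F)cc(C(F)(F)F)c1` gives 2500 nM in this assay, and compound 3 `O=S(=O)(NCCCNCc1ccc(Br)cc1)c1cc(C(F)(F)F)cc(C(F)(F)F)c1` gives 1900 nM. The three numbers sit close together: a 1.3-fold higher number from compound 1 to compound 2 (0.12 log units; within the scatter), no change at the digits printed from compound 1 to compound 3 (within the scatter), and a 1.3-fold lower number from compound 2 to compound 3 (0.12 log units; within the scatter). Compound 1 thus stands level with compound 3 at the digits reported, the pair being the lowest of the three, with every step among the measured compounds within the scatter.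

Compound 4 `COc1ccc(CNCCCNS(=O)(=O)c2cc(C(F)(F)F)cc(C(F)(F)F)c2)cc1` differs from compound 1 in one place: hydrogen in place of methoxy on an aromatic carbon. Among the measured compounds shown here, no measured step repeats this change; each measured step exchanges the whole group on the saturated chain carbon bound to the amine nitrogen, and none of those exchanges moved the number beyond the scatter. The data therefore give no reason to expect a step beyond the scatter, and the expected step is a 1.1-fold higher number from compound 1 to compound 4 (0.02 log units; within the scatter). Compound 4 is estimated at 2000 nM, expected to fall between 1000 nM and 4000 nM.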

Compound 4, concentration for 50% growth inhibition: 2500 nM
Estimate against measurement, compound 4: 1.3-fold (0.10 log units) below, within the range that was stated.
By their numbers in this assay, from the lowest: compounds 1, 3, 2 and 4 (each within the scatter of the next).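

In this assay, among these compounds, this is the first measured change at this aromatic carbon itself: hydrogen in place of methoxy gives only a small step (a 1.3-fold higher number from compound 1 to compound 4 (0.12 log units; within the scatter)), so 3,4-dimethoxyphenyl can become 4-methoxyphenyl without a step beyond the scatter. The 4-methoxyphenyl compound also stays within the scatter of the compounds carrying the other two groups, whether methoxy stands in place of bromo (a 1.3-fold higher number from compound 3 to compound 4 (0.12 log units; within the scatter)) or 4-methoxyphenyl in place of 2,3-dihydro-1,4-benzodioxin-2-yl (no change at the digits printed from compound 2 to compound 4 (within the scatter)). No measurement offered here accounts for these small steps.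

The compounds shown leave open whether the remaining methoxy group could also give way to hydrogen with as small a step. They also do not tell whether an amine or a carboxylic acid on this aromatic carbon, or a longer chain in the linker, would give a step beyond the scatter.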